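A few compounds are considered here, and "the series" means these few. Any claim that something is new, unique, unknown or untested is made for them only; others in the source may bear on it.

Among the compounds with values here, compound 2 `CC(O)(C#Cc1ccc(N2CC3CC2CN3)c(Nc2ncnc3[nH]ccc23)c1)c1nccs1` gives 200 nM in an assay for inhibition of mitogen-activated protein kinase kinase kinase 14 (Homo sapiens), read by luminescence and ADP-Glo, with a stated time of 120 min, in the presence of a further agent that is not named here (a higher number here means a weaker inhibitor, a lower number a stronger inhibitor), the higher of the two numbers measured so far, whereas compound 1 `CN(C)c1ccc(C#CC(C)(O)c2nccs2)cc1Nc1ncnc2[nH]ccc12` gives 22.5 nM. Within the data shown here, the only measured step, an 8.9-fold higher number from compound 1 to compound 2 (0.95 log units; beyond the scatter), came from exchanging the group on one aromatic carbon of the shared core. Compound 3 `CCS(=O)(=O)N1CCN(c2ccc(C#CC(C)(O)c3nccs3)cc2Nc2ncnc3[nH]ccc23)CC1` changes that same carbon once more: a group of 11 heavy atoms (6 carbon, 2 nitrogen, 2 oxygen, 1 sulfur; one six-membered non-aromatic ring with 2 hetero atoms) in place of a group of 7 heavy atoms (5 carbon, 2 nitrogen; 2 five-membered non-aromatic rings with 1 hetero atom each), on an aromatic carbon. The step from compound 1 to compound 2 bears on this only loosely: it shows that exchanging the group on this carbon can move the number beyond the scatter, but the group entering compound 3 resembles neither earlier group, so neither its direction nor its size can be read off directly. On that thin basis compound 3 is expected to land somewhere between the two measured numbers, estimated at 70 nM, with a range from 18 nM to 280 nM. That estimate means an expected 2.9-fold lower number from compound 2 to compound 3 (0.46 log units; beyond the scatter).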

Compound 3, half-maximal inhibitory concentration: 8.22 nM
Compound 3: middle estimate off by 8.5-fold (0.93 log units), on the high side; measured number below the stated range.
By their numbers in this assay, from the lowest: compound 3; then compound 1; then compound 2.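

In this assay, placing 4-(ethylsulfonyl)piperazin-1-yl on this aromatic carbon, in place of the group with two five-membered non-aromatic rings, gives a 24-fold lower number from compound 2 to compound 3 (1.39 log units; beyond the scatter). A large group here can therefore bring the number down as well as up, and the new group also goes past the small dimethylamino group, with a 2.7-fold lower number from compound 1 to compound 3 (0.44 log units; beyond the scatter). Across these compounds the number does not follow group size: the group with the most heavy atoms gives the lowest number, while dimethylamino, with the fewest, sits in the middle. No measurement here explains these differences.

Still open, as far as these compounds go, is which part of the entering group matters. An unsubstituted piperazine, or a piperazine carrying methylsulfonyl or acetyl, would help separate the contribution of the ring from that of the ethylsulfonyl group.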